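Cyclic amine in place of an open-chain pyridinylmethylamino

The compounds below may be only part of what the source reports. "The series", "measured", "known", "first", "only" and "open" are said of these compounds alone.

Measured compounds:
compound 1 `CC(C(=O)NCc1ccc(C(F)(F)F)nc1NCc1cccnc1)c1ccc(NS(C)(=O)=O)c(F)c1`, in a functional assay on CHO-K1 cells for antagonist activity at transient receptor potential cation channel subfamily V member 1 (Homo sapiens), read by FLIPR (on this read-out higher numbers stand for weaker inhibition and lower numbers for stronger inhibition), compound 1 gives "not active" (no number reported)
compound 2 `CC1CCCN1c1nc(C(F)(F)F)ccc1CNC(=O)[C@@H](C)c1ccc(NS(C)(=O)=O)c(F)c1`, in this assay compound 2 gives 0.3 nM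

Compound 1 has no number of its own in this assay: it is reported as not active, so no place on the scale can be assigned to it. Compound 2, which carries a cyclic amine on the same aromatic carbon and is a single stereoisomer, gives a very low value in this assay.

Compound 3 `CC(C(=O)NCc1ccc(C(F)(F)F)nc1N1CCC(C(F)(F)F)CC1)c1ccc(NS(C)(=O)=O)c(F)c1` differs from compound 1 by 4-(trifluoromethyl)piperidin-1-yl in place of ((pyridin-3-yl)methyl)amino on an aromatic carbon. Among the measured compounds shown here, no measured step links the two, so the size of the step in this assay cannot be computed; compound 3 is expected to move well beyond the scatter in the direction of stronger inhibition, from no detectable activity to a measurable number, in line with the cyclic amine seen in compound 2.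

Compound 3 is estimated at 3 nM, with a range from 0.5 nM to 30 nM.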

Compound 3, inhibition constant: 0.6 nM
Compound 3: middle estimate off by 5.0-fold (0.70 log units), on the high side; low and high end bracket the measured number.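

No step can be read from compound 1 to compound 3: in this assay compound 1 gives "not active" (no number reported), while compound 3 gives 0.6 nM. The compounds shown leave open how large the change from ((pyridin-3-yl)methyl)amino to 4-(trifluoromethyl)piperidin-1-yl is. No measurement shown bears on what underlies this result.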